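This account rests on a few compounds, and the source may have more. Where it says the series, first, only, none or still open, it means among the compounds named here.

In a functional assay on Huh-7 cells (Homo sapiens) for cytotoxicity, read by MTT assay, with a stated time of 72 h (on this read-out higher numbers stand for lower toxicity in this test and lower numbers for higher toxicity in this test), compound 1 (`CCCS(=O)(=O)N1CCC2(CC1)OOC(C)(CC)OO2`) gives > 100 ug/mL, which is a limit of the assay and not a number. Compound 2 (`CCCS(=O)(=O)N1CCC2(CC1)OOC(C)(c1ccccc1)OO2`) gives > 100 ug/mL, again only a limit, so no number places it. Neither compound has a measured value: the limit of > 100 ug/mL in this assay, at which 2 of the 2 values shown sit. Compound 3 (`CCCS(=O)(=O)N1CCC2(CC1)OOC(C)(c1ccc(Cl)cc1)OO2`) differs from compound 2 by chloro in place of hydrogen on an aromatic carbon, para to a large group, turning phenyl into 4-chlorophenyl: chloro in place of hydrogen on an aromatic carbon. Within the data shown here, the only measured step that bears on this is a step that the two limits leave unreadable from compound 1 to compound 2, and it offers no size to carry over. No change beyond the scatter is therefore expected in this assay, and no direction can be argued. The expected step is a step that the limit leaves unreadable from compound 2 to compound 3. For compound 3 the estimated value is 110 ug/mL, within an expected range from 50 ug/mL to 200 ug/mL.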

Compound 3, half-maximal cytotoxic concentration: > 100 ug/mL
Compound 3 was reported as a limit (the forecaster's own chance of this, stated with the estimate: 75%); the middle value is on the limit's open side.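

No step among compound 1, compound 2 and compound 3 can be read in this assay, as all three values are limits and not numbers: the limit of > 100 ug/mL in this assay, at which 3 of the 3 values shown sit.

The compounds shown leave open where any of their half-maximal cytotoxic concentrations lies, and whether phenyl, 4-chlorophenyl or ethyl makes any difference to it.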